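This account rests on a few compounds, and the source may have more. Where it says the series, first, only, none or still open, it means among the compounds named here.

Of the compounds shown here, three sharing one core have been measured in a functional assay on HCT-116 cells (Homo sapiens) for antiproliferative activity, read by MTT assay, with a stated time of 72 h; on this read-out higher numbers stand for weaker inhibition and lower numbers for stronger inhibition. Compound 3 `COc1ccc(/C=C2\S/C(=N\c3c(C)cccc3C)N(C)C2=O)cc1` gives > 100000 nM, which is a limit of the assay and not a number. Compound 4 `COc1ccc(/C=C2\S/C(=N\c3ccc(C)cc3)N(C)C2=O)cc1` has not yet been measured. It differs from compound 3 by 4-methylphenyl in place of 2,6-dimethylphenyl on a double-bonded nitrogen.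

For the measured compounds named here, no measured compound carries the 4-methylphenyl group itself, so the closest guides are two relatives with a similarly named group at that place. Compound 1 `COc1ccc(/C=C2\S/C(=N\c3ccc(Br)cc3)N(C)C2=O)cc1`, with 4-bromophenyl, gives 17000 nM, and compound 2 `COc1ccc(/C=C2\S/C(=N\c3ccc(F)cc3)N(C)C2=O)cc1`, with 4-fluorophenyl, gives 13300 nM. Between these two the data show a 1.3-fold lower number from compound 1 to compound 2 (0.11 log units; within the scatter), so exchanging one of those groups for the other made no clear difference.

Replacing either group with 2,6-dimethylphenyl had a far larger effect, with an at least 5.8-fold higher number from compound 1 to compound 3 (0.76 log units; beyond the scatter) and an at least 7.5-fold higher number from compound 2 to compound 3 (0.87 log units; beyond the scatter). The step to compound 4 leaves that same 2,6-dimethylphenyl group, so it should run back the opposite way, towards stronger inhibition.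

The expected step is an at least 6.6-fold lower number from compound 3 to compound 4 (0.82 log units; beyond the scatter). For compound 4 the estimated value is 15000 nM, with an expected range from 6000 nM to 40000 nM.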

Compound 4, half-maximal inhibitory concentration: > 100000 nM
Compound 4: no number, only a limit; the forecaster's own chance of this, stated with the estimate: 5%; middle value at least 6.6-fold (0.82 log units) away from the limit.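

In this assay, for the compounds shown here, compound 4 gives only a limit and not a number, so its step from compound 3 cannot be read, and both compounds sit at the same ceiling: the limit of > 100000 nM in this assay, at which 2 of the 4 values shown sit. The earlier compounds linked the loss of inhibition to the 2,6-dimethylphenyl group, but the 4-methylphenyl group on the double-bonded nitrogen also loses it, with methyl in place of fluoro giving an at least 7.5-fold higher number from compound 2 to compound 4 (0.87 log units; beyond the scatter) and methyl in place of bromo giving an at least 5.8-fold higher number from compound 1 to compound 4 (0.76 log units; beyond the scatter). Among these four compounds, therefore, a second methyl on the ring is not needed for the loss, and only the 4-bromophenyl and 4-fluorophenyl compounds give measurable numbers.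

The compounds shown leave open whether this split extends beyond these groups, for example to a plain phenyl ring, 4-chlorophenyl, 4-methoxyphenyl or 4-aminophenyl at the same place. They also leave open how compound 3 and compound 4 would compare in an assay that could give a number for each.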